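A few compounds are considered here, and "the series" means these few. Any claim that something is new, unique, unknown or untested is made for them only; others in the source may bear on it.

Compound 1 `O=C(Nc1ccc(F)c(-c2nc3ncc(-c4ccc(F)cc4F)cc3[nH]2)c1)N1CCCC1` gives 32400 nM in an ADME assay on HepG2 cells (Homo sapiens) for cytotoxicity, read by resazurin assay, with a stated time of 48 h; on this read-out lower numbers stand for an effect already at smaller amounts and higher numbers for an effect only at larger amounts of compound.
Compound 2 `O=C(Nc1ccc(F)c(-c2nc3ncc(-c4ccc(F)cc4)cc3[nH]2)c1)N1CCCC1` gives in this assay only a limit of the assay, > 50000 nM.
Compound 3 `O=C(Nc1ccc(F)c(-c2nc3ncc(-c4cccc(F)c4)cc3[nH]2)c1)N1CCCC1` gives 28200 nM in this assay.

All three share one core and differ only in the fluorinated ring attached to it. Compound 1 carries one more fluoro than compound 2: fluoro in place of hydrogen on an aromatic carbon. That change gave an at least 1.5-fold lower number from compound 2 to compound 1 (0.18 log units; that floor lies within the scatter), and since compound 2 sits at the limit (the limit of > 50000 nM in this assay, at which 1 of the 3 values shown sits), the true size of that step is not known. Compound 3 differs from compound 2 in where its single fluoro sits: 3-fluorophenyl in place of 4-fluorophenyl on an aromatic carbon. Compound 3 and compound 1 lie close together, as a 1.1-fold lower number from compound 1 to compound 3 (0.06 log units; within the scatter) shows.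

Compound 4 `O=C(Nc1ccc(F)c(-c2nc3ncc(-c4cc(F)cc(F)c4)cc3[nH]2)c1)N1CCCC1` is not yet measured. It stands to compound 3 as compound 1 stands to compound 2: fluoro in place of hydrogen on an aromatic carbon. The surroundings differ, one fluoro sitting ortho to a large group and the other meta to a large group, so this is the same kind of change rather than the same one. Because the earlier step of an at least 1.5-fold lower number from compound 2 to compound 1 (0.18 log units; that floor lies within the scatter) stayed within the scatter, a similarly small step is expected here, a 1.2-fold lower number from compound 3 to compound 4 (0.07 log units; within the scatter). Compound 4 is therefore estimated at 24000 nM, somewhere between 10000 nM and 50000 nM.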

Compound 4, half-maximal effective concentration: > 50000 nM
Compound 4: only a limit was reported; the forecaster's own chance of this, stated with the estimate: 25%; middle value at least 2.0-fold (0.31 log units) away from the limit.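

In this assay, the added fluoro gave an at least 1.7-fold higher number from compound 3 to compound 4 (0.24 log units; that floor lies within the scatter), whereas the same kind of change ran the other way in the earlier pair, so it does not carry over unchanged from one core to the other: the same change on two cores in this assay, an at least 1.5-fold lower number (0.18 log units; that floor lies within the scatter) from compound 2 to compound 1 and an at least 1.7-fold higher number (0.24 log units; that floor lies within the scatter) from compound 3 to compound 4, at least 2.7-fold (0.43 log units) apart, beyond the scatter of two such steps
Against compound 1, the 3,5-difluorophenyl group gave an at least 1.5-fold higher number from compound 1 to compound 4 (0.18 log units; that floor lies within the scatter), while the step between compound 2 and compound 4 cannot be read. This shows that the added fluoro has no single fixed effect across these two pairs, but it does not show how large any of these steps truly is, as compound 2 and compound 4 each give only a limit: the limit of > 50000 nM in this assay, at which 2 of the 4 values shown sit.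

From the compounds shown here alone, the true values of compound 2 and compound 4 remain open. Going by these compounds, what sets the two pairs apart also remains open. On these data alone, whether a chloro or a methoxy group in place of the added fluoro would behave the same way also stays open.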